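Adding a Ring at the Core Nitrogen

The source may hold more compounds than are shown below. What is called first, only, known or untested is meant among the compounds shown, and "the series" means these compounds.

In a functional assay on BT-474 cells (Homo sapiens) for inhibition, read by MTT assay, with a stated time of 5 days (a lower number here means a stronger inhibitor, a higher number a weaker inhibitor), compound 1 `Cc1cc(Nc2nc(NCc3ccc(Cl)cc3)nc3[nH]ncc23)n[nH]1` gives 11700 nM and compound 2 `Cc1cc(Nc2nc(NCc3ccc(C#N)cc3)nc3[nH]ncc23)n[nH]1` gives 12100 nM, so the two stand level. Compound 3 `Cc1cc(Nc2nc(NCc3ccc(Cl)cc3)nc3c2cnn3C2CCOCC2)n[nH]1` differs from compound 1 by oxan-4-yl in place of hydrogen on an aromatic nitrogen, with oxan-4-yl in place of hydrogen on an aromatic nitrogen. For the measured compounds named here, the only measured step, a 1.0-fold higher number from compound 1 to compound 2 (0.01 log units; within the scatter), is a change of cyano for chloro on an aromatic carbon, so it says little about this nitrogen. With so little evidence, only a modest gain in this assay is expected, an estimated 2.0-fold lower number from compound 1 to compound 3 (0.29 log units; within the scatter). For compound 3 the estimated value is 6000 nM, with an expected range of 1500 nM to 25000 nM.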

Compound 3, half-maximal inhibitory concentration: 18300 nM
Beside the measured number, compound 3's estimate is 3.1-fold (0.48 log units) below it, within the range that was stated.
By their numbers in this assay, from the lowest: compounds 1, 2 and 3 (each within the scatter of the next).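

In this assay the step to oxan-4-yl on the aromatic nitrogen is a 1.6-fold higher number from compound 1 to compound 3 (0.19 log units; within the scatter) and so shows that this nitrogen can carry a whole six-membered ring in place of its hydrogen while the reading stays level. The modest gain expected did not appear, and this position has so far produced no clear shift in either direction. Nothing measured here explains the result.

Still open, going by these compounds, is whether a methyl group or piperidin-4-yl, a ring holding an amine, on this nitrogen would move the number beyond the scatter. Also open, on these data alone, is whether oxan-4-yl behaves the same way with the nitrile of compound 2.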